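Amide aryl variation on the shared core

The compounds below may be only part of what the source reports. "The series", "measured", "known", "first", "only" and "open" are said of these compounds alone.

Two compounds of the series have been run in a functional assay on T47D cells (Homo sapiens) for inhibition, read by CCK-8 assay, with a stated time of 72 h, tested at 1 uM; a higher number here means more inhibition of growth at the concentration tested, a lower number less inhibition of growth. Compound 1 `COc1ccc(NC(=O)C2(C(=O)Nc3ccc(Nc4ncc5cc(C(=O)N(C)C)n(C6CCCC6)c5n4)cc3)CC2)cc1` gives 76.4%. Compound 2 `CN(C)C(=O)c1cc2cnc(Nc3ccc(NC(=O)C4(C(=O)Nc5ccccc5F)CC4)cc3)nc2n1C1CCCC1` gives 85.2%. Compound 2 holds the higher of the two numbers, yet the step of a number 8.8 percentage points higher from compound 1 to compound 2 (within the scatter) lies within the scatter, so the two stand level in practice. Compound 3 `CN(C)C(=O)c1cc2cnc(Nc3ccc(NC(=O)C4(C(=O)Nc5cccc(C(F)(F)F)c5)CC4)cc3)nc2n1C1CCCC1` is not yet measured; it differs from compound 2 by 3-(trifluoromethyl)phenyl in place of 2-fluorophenyl on an amide-type nitrogen. For the measured compounds named here, the one measured step that touches the same amide-type nitrogen, a number 8.8 percentage points higher from compound 1 to compound 2 (within the scatter), stayed within the scatter, and no measured compound carries a 3-(trifluoromethyl)phenyl there, so the data give no ground for a shift in either direction. The expected step is therefore a number 4.2 percentage points lower from compound 2 to compound 3 (within the scatter), nothing beyond the scatter. Compound 3 is estimated at 81%, with a range from 62% to 95%.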

Compound 3, percent growth inhibition at one concentration: 9.7%
For compound 3 the middle estimate is 71.3 percentage points above the measured one, outside the stated range (below it).
By their numbers in this assay, from the lowest: compound 3; then compounds 1 and 2 (each within the scatter of the next).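

This amide-type nitrogen does not tolerate every aryl group: in this assay, 3-(trifluoromethyl)phenyl gives a number 75.5 percentage points lower from compound 2 to compound 3 (beyond the scatter) and a number 66.7 percentage points lower from compound 1 to compound 3 (beyond the scatter), whereas the earlier exchange between 4-methoxyphenyl and 2-fluorophenyl stayed within the scatter. The choice of aryl group at this one place can therefore separate marked growth inhibition from very little at the concentration tested, with the rest of the structure unchanged. No measurement at hand speaks to the origin of this loss.

With only compound 3 carrying a trifluoromethyl group, the compounds shown do not separate the contribution of that group from that of its place on the ring. They also leave open how a plain phenyl, or an aryl ring bearing a nitrile or a carboxylic acid, would fare on this nitrogen.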